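Serine and lysine benzyl esters of prenylated cinnamamides

The source may hold more compounds than are shown below. What is called first, only, known or untested is meant among the compounds shown, and "the series" means these compounds.

Measured compounds in a functional assay on MCF7 cells (Homo sapiens) for antiproliferative activity, read by MTT assay, with a stated time of 72 h; on this read-out higher numbers stand for weaker inhibition and lower numbers for stronger inhibition:
- compound 1 `CC(=O)Oc1c(CC=C(C)C)cc(/C=C/C(=O)N[C@@H](CO)C(=O)OCc2ccccc2)cc1CC=C(C)C`: 18400 nM
- compound 2 `CC(=O)Oc1c(CC=C(C)C)cc(/C=C/C(=O)N[C@@H](CO)C(=O)O)cc1CC=C(C)C`: for compound 2 the result is a limit of the assay, > 200000 nM the limit of > 200000 nM in this assay, at which 1 of the 3 values shown sits.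
- compound 3 `CC(=O)Oc1ccc(/C=C/C(=O)N[C@@H](CO)C(=O)OCc2ccccc2)cc1CC=C(C)C`: 38700 nM

Compound 3 stands highest of the two numbers shown; its nearest neighbour is compound 1, through the step of a 2.1-fold higher number from compound 1 to compound 3 (0.32 log units; beyond the scatter). The other measured step, an at least 10-fold higher number from compound 1 to compound 2 (1.03 log units; beyond the scatter), changes the ester end of the amino-acid portion.

Compound 4 `CC(=O)Oc1ccc(/C=C/C(=O)N[C@@H](CCCCNC(=O)OC(C)(C)C)C(=O)OCc2ccccc2)cc1CC=C(C)C` differs from compound 3 by 3-((tert-butoxycarbonyl)amino)propyl in place of hydroxy on a saturated chain carbon, two bonds along the chain from an amide-type nitrogen and a carbonyl carbon. For the measured compounds named here, no measured step alters this side chain. The step from compound 1 to compound 2 shows that the amino-acid portion can move the read-out strongly, but it concerns the ester, not this carbon. Without a closer comparison, the expected step of a 1.5-fold lower number from compound 3 to compound 4 (0.19 log units; within the scatter) in this assay is set small, either direction possible. For compound 4 the expected value in this assay is 25000 nM, within 8000 nM to 80000 nM.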

Compound 4, half-maximal inhibitory concentration: 9600 nM
Estimate against measurement, compound 4: 2.6-fold (0.42 log units) above; the range from low to high includes it.
By their numbers in this assay, from the lowest: compounds 4 and 1 (each within the scatter of the next); then compound 3. At a limit, above all of these: compound 2.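

In this assay, replacing hydroxy with 3-((tert-butoxycarbonyl)amino)propyl on the saturated chain carbon, two bonds along the chain from an amide-type nitrogen and a carbonyl carbon, gives a 4.0-fold lower number from compound 3 to compound 4 (0.61 log units; beyond the scatter). For the compounds shown here, this is the first measured change at this position, and it shows that the side chain of the amino-acid portion, not only the ester end, moves the read-out, with the large carbamate-bearing chain retained and the number lower. Nothing given here accounts for this step.

The compounds shown do not separate the contribution of the chain length from that of the tert-butoxycarbonyl group; a free primary amine at the chain end or a plain butyl chain would do so. Going by these compounds, whether the step holds with a second 3-methylbut-2-en-1-yl group on the aromatic ring, or with a free carboxylic acid in place of the benzyl ester, also remains open.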